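The source may hold more compounds than are shown below. What is called first, only, known or untested is meant among the compounds shown, and "the series" means these compounds.

Among the measured compounds shown here, in a functional assay on HepG2 cells (Homo sapiens) for cytotoxicity, read by MTT assay, with a stated time of 48 h (on this read-out higher numbers stand for weaker inhibition and lower numbers for stronger inhibition), compound 1 (`COc1ccc(-c2nnc(SCCn3c([N+](=O)[O-])cnc3C)o2)cc1`) gives 5800 nM, while compound 2 (`Cc1ccc(-c2nnc(SCCn3c([N+](=O)[O-])cnc3C)o2)c(O)c1`) gives 16600 nM, the higher of the two numbers so far. Compound 3 (`Cc1ncc([N+](=O)[O-])n1CCSc1nnc(-c2cccnc2)o1`) differs from compound 2 at one place: pyridin-3-yl in place of 2-hydroxy-4-methylphenyl on an aromatic carbon. For the measured compounds named here, the only measured step at this place is modest, a 2.9-fold higher number from compound 1 to compound 2 (0.46 log units; beyond the scatter). Going by the values given here, no compound with pyridin-3-yl has been measured, so that step offers only a rough guide to size. Compound 1 suggests that leaving 2-hydroxy-4-methylphenyl may lower the number in this assay, though probably by a small amount. The expected change is a 1.7-fold lower number from compound 2 to compound 3 (0.22 log units; within the scatter). For compound 3, the estimate is 10000 nM, with an expected range of 3500 nM to 30000 nM.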

Compound 3, half-maximal inhibitory concentration: 9600 nM
For compound 3 the middle estimate is 1.0-fold (0.02 log units) above the measured one; the measured number falls inside the stated range.
By their numbers in this assay, from the lowest: compounds 1, 3 and 2 (each within the scatter of the next, the first and the last beyond it).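

In this assay, pyridin-3-yl on this aromatic carbon cannot be told apart from either earlier group: the steps are a 1.7-fold lower number from compound 2 to compound 3 (0.24 log units; within the scatter) and a 1.7-fold higher number from compound 1 to compound 3 (0.22 log units; within the scatter), although compound 1 and compound 2 lie beyond the scatter of each other. A ring with one hetero atom therefore sits here with no readable change from either ring of carbon only. Nothing available gives a reason for this. From the compounds shown here alone, whether an amine or a carboxylic acid on the ring at this carbon would move the number remains open.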